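Working notes: methoxy for bromo on the aromatic ring

A few compounds are considered here, and "the series" means these few. Any claim that something is new, unique, unknown or untested is made for them only; others in the source may bear on it.

Measured in an assay on isolated protein for inhibition of protein deacetylase HDAC6 (Homo sapiens), read by fluorescence, with a stated time of 1 h, tested at 100 nM; a higher number here means more inhibition at the concentration tested (going by the name of the read-out), a lower number less inhibition:
compound 1, `Cc1cccc(CN2CCC(c3noc(COc4ccc(/C=C/C(=O)NO)cc4)n3)CC2)c1`: 73%
compound 2, `O=C(/C=C/c1ccc(OCc2nc(C3CCN(Cc4ccc(Br)cc4)CC3)no2)cc1)NO`: 58%

Compound 2 stands lowest of the two numbers in this assay; compound 1 is the nearer, higher one. Compound 3 is `COc1ccc(CN2CCC(c3noc(COc4ccc(/C=C/C(=O)NO)cc4)n3)CC2)cc1`. It differs from compound 2 in one place: methoxy in place of bromo on an aromatic carbon. For the measured compounds named here, the single measured step, a number 15 percentage points lower from compound 1 to compound 2 (beyond the scatter), alters the same six-membered aromatic ring of carbon only, with a different pair of groups, and shows that such a change can shift the number modestly; no measured step exchanges bromo for methoxy. Compound 3 is therefore expected close to compound 2 in this assay, an estimated step of a number 4 percentage points higher from compound 2 to compound 3 (within the scatter) that may stay within the scatter. The estimate for compound 3 is 62%, range 45% to 78%.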

Compound 3, a percentage reported as inhibition, at one concentration (the size of the read-out at that concentration, not a potency): 75%
The estimate for compound 3 lay 13 percentage points below the measured number; the measured number falls inside the stated range.
By their numbers in this assay, from the lowest: compound 2; then compounds 1 and 3 (each within the scatter of the next).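

In this assay the change to methoxy gives a number 17 percentage points higher from compound 2 to compound 3 (beyond the scatter), so the number at this aromatic carbon depends on the group it carries. With a number 2 percentage points higher from compound 1 to compound 3 (within the scatter), a 4-substituted benzyl group does not by itself bring the lower number; among these compounds, only compound 2, with bromo, stands lower. Still open, from the compounds shown here alone, is whether an amine, a nitrile or a carboxylic acid on the same carbon would stay level with methoxy or fall towards bromo. The data at hand offer no explanation for the difference between bromo and methoxy.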